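The source may hold more compounds than are shown below. What is called first, only, known or untested is meant among the compounds shown, and "the series" means these compounds.

Measured in a functional assay on HCT-15 cells (Homo sapiens) for cytotoxicity, read by sulforhodamine B assay, with a stated time of 72 h; on this read-out higher numbers stand for weaker inhibition of growth and lower numbers for stronger inhibition of growth:
- compound 1 `CCCC(=O)N1c2ccccc2CCC1C(=O)Nc1ccccc1C(F)(F)F` gives > 70000 nM, a limit of the assay
- compound 2 `CCC(=O)N1c2ccccc2CCC1C(=O)Nc1ccccc1C(F)(F)F` gives > 80000 nM, a limit of the assay
- compound 3 `O=C(Nc1ccccc1C(F)(F)F)C1CCc2ccccc2N1C(=O)c1ccc(Cl)cc1` gives 839 nM

Among the measured compounds shown here, compound 3 holds the only actual number in this set, as the other two values are limits. Compound 4 `O=C(Nc1ccccc1C(F)(F)F)C1CCc2ccccc2N1C(=O)c1ccccc1Cl` is next, with 2-chlorophenyl in place of 4-chlorophenyl on a carbonyl carbon.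

Two measured steps changed the group at this same place, both large: an at least 83-fold lower number from compound 1 to compound 3 (1.92 log units; beyond the scatter) and an at least 95-fold lower number from compound 2 to compound 3 (1.97 log units; beyond the scatter). The step that the two limits leave unreadable from compound 1 to compound 2 cannot be read. For the measured compounds named here, each large step replaces a chain with 4-chlorophenyl, and no measured step compares chlorophenyl isomers, so the size of the new step is poorly constrained.

Compound 4 keeps a chlorophenyl on that carbonyl carbon, so it is expected to stay close to compound 3 at 839 nM, with no step beyond the scatter as the central expectation. The expected step is a 1.5-fold higher number from compound 3 to compound 4 (0.19 log units; within the scatter). The estimated value for compound 4 is 1300 nM, with an expected range of 250 nM to 8000 nM.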

Compound 4, concentration for 50% growth inhibition: 4220 nM
Beside the measured number, compound 4's estimate is 3.2-fold (0.51 log units) below it; the measured number falls inside the stated range.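

In this assay the place of the chlorine on the phenyl group now registers on its own: 2-chlorophenyl in place of 4-chlorophenyl gives a 5.0-fold higher number from compound 3 to compound 4 (0.70 log units; beyond the scatter) and shows that the two isomers on this carbonyl carbon are not interchangeable. The earlier gain over the chains therefore depends partly on which chlorophenyl isomer is present. Compound 4 still retains much of that gain, with an at least 18-fold lower number from compound 2 to compound 4 (1.27 log units; beyond the scatter) and an at least 16-fold lower number from compound 1 to compound 4 (1.21 log units; beyond the scatter) as steps that rest on limits of the assay for the two chain compounds, whose own step cannot be read.

From the compounds shown here alone, whether the chlorine contributes at all, and how unsubstituted phenyl or 4-methoxyphenyl would compare on this carbonyl carbon, stays open. Nothing shown gives a reason for the gap between the two chlorophenyl isomers.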